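Swapping Bromophenyl for Dihydroxyphenyl on a Shared Core

The compounds below may be only part of what the source reports. "The series", "measured", "known", "first", "only" and "open" are said of these compounds alone.

Three compounds carry numbers in a functional assay on MCF7 cells (Homo sapiens) for cytotoxicity, read by MTT assay, with a stated time of 4 h; a higher number here means a weaker inhibitor, a lower number a stronger inhibitor:
compound 1 `O=C1N=C(NN2Cc3ccccc3N=C2c2ccccc2)S/C1=C/c1ccc(Br)cc1` gives 2300 nM;
compound 2 `COc1ccc(/C=C2/SC(NN3Cc4ccccc4N=C3c3ccccc3)=NC2=O)cc1OC` gives 1000 nM;
compound 3 `CCc1ccc(NCC(=O)Nn2c(-c3ccccc3)nc3ccccc3c2=O)cc1` gives 2420 nM.

Among these three, compound 1 holds the second highest number. Compound 3 is its nearest neighbour, and the two lie within the scatter of each other, so no order between them can be claimed. Compound 2 lies furthest away, on the lower side.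

Compound 4 `O=C1N=C(NN2Cc3ccccc3N=C2c2ccccc2)S/C1=C/c1ccc(O)cc1O` has not yet been measured. It differs from compound 1 by 2,4-dihydroxyphenyl in place of 4-bromophenyl on a double-bonded chain carbon bound to a double-bonded ring carbon. For the measured compounds named here, one measured step bears on this change: the move from compound 1 to compound 2 replaces the same 4-bromophenyl at the same place with 3,4-dimethoxyphenyl and yields a 2.3-fold lower number from compound 1 to compound 2 (0.36 log units; beyond the scatter). Going by the values given here, the group entering compound 4 is not the same, carrying hydroxyl rather than methoxy groups, and no measured step involves a dihydroxyphenyl, so the precedent is indirect. On that single step, a modest drop in the number, or none beyond the scatter, is expected.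

Compound 4 is therefore estimated at 1500 nM, with a likely range from 600 nM to 4000 nM. That estimate corresponds to an expected step of a 1.5-fold lower number from compound 1 to compound 4 (0.19 log units; within the scatter).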

Compound 4, half-maximal inhibitory concentration: 7490 nM
Estimate against measurement, compound 4: 5.0-fold (0.70 log units) below; the whole stated range lies below it.
By their numbers in this assay, from the lowest: compound 2; then compounds 1 and 3 (each within the scatter of the next); then compound 4.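

For the compounds shown here, at the position on a double-bonded chain carbon bound to a double-bonded ring carbon, the earlier compounds offered only one replacement for 4-bromophenyl, and that replacement lowered the number; in this assay, 2,4-dihydroxyphenyl instead moves it the other way, with a 3.3-fold higher number from compound 1 to compound 4 (0.51 log units; beyond the scatter). The direction of change at this place therefore depends on which substituted phenyl enters, and having oxygen-bearing groups on the ring does not by itself lower the number, since 2,4-dihydroxyphenyl in place of 3,4-dimethoxyphenyl gives a 7.5-fold higher number from compound 2 to compound 4 (0.87 log units; beyond the scatter). Nothing available here accounts for this difference between the two groups.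

The step between compound 2 and compound 4 changes both the kind of oxygen group and the pattern on the ring, so the compounds shown cannot separate the effect of hydroxyl from that of its placement; 2,4-dimethoxyphenyl or 3,4-dihydroxyphenyl at this place would be needed to do so. They also leave open whether a single hydroxyl, as in 4-hydroxyphenyl, or an amine, as in 4-aminophenyl, would follow compound 2 or compound 4 in this assay.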